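The source may report more compounds than this note shows. Statements on the series, on what has been measured and on what is new or still open speak of the compounds shown alone.

Compound 1 `CCCCCCCCCCCCCCNC(=O)[C@H](CO)/N=C/c1ccc(OC)cc1` measures 81700 nM
Compound 2 `CCCCCCCCCCCCCCNC(=O)[C@H](CO)/N=C/c1ccccc1[N+](=O)[O-]` measures 82600 nM
Compound 3 `CCCCCCCCCCCCCCNC(=O)[C@H](CO)/N=C/c1ccc(O)cc1` measures 71700 nM

All three values come from an ADME assay on HEK293 cells (Homo sapiens) for cytotoxicity (a higher number here means a weaker inhibitor, a lower number a stronger inhibitor), and the three compounds differ only in the aromatic group on a carbon with a double bond to nitrogen. On these numbers, compound 3 cannot be told apart from the other two: a 1.1-fold lower number from compound 1 to compound 3 (0.06 log units; within the scatter) and a 1.2-fold lower number from compound 2 to compound 3 (0.06 log units; within the scatter) are the steps that link it to them.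

The next compound to be tested is compound 4 `CCCCCCCCCCCCCCNC(=O)[C@H](CO)/N=C/c1cccc(Cl)c1`, which has 3-chlorophenyl in place of 4-hydroxyphenyl at that same place (3-chlorophenyl in place of 4-hydroxyphenyl on a carbon with a double bond to nitrogen). Going by the values given here, all the measured steps bear on this change, as each one alters the same aromatic group. Besides the two steps to compound 3, there is a 1.0-fold higher number from compound 1 to compound 2 (0.00 log units; within the scatter), and none of the three goes beyond the scatter. Among the compounds with values here, none of the measured compounds carries a chlorine, however, so the new group itself remains untested and the range has to stay wide.

The estimated change is a 1.0-fold higher number from compound 3 to compound 4 (0.02 log units; within the scatter), so no step beyond the scatter is expected in either direction. For compound 4 the expected value is 75000 nM, with an estimated range from 42000 nM to 125000 nM as the likely span of the measurement.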

Compound 4, half-maximal inhibitory concentration: 77000 nM
Compound 4: middle estimate off by 1.0-fold (0.01 log units), on the low side; measured number inside the range.
By their numbers in this assay, from the lowest: compounds 3, 4, 1 and 2 (each within the scatter of the next).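

Placed on a carbon with a double bond to nitrogen, 3-chlorophenyl brings a chlorine to this position for the first time and has no hydrogen-bond donor or acceptor in the count, unlike the 4-hydroxyphenyl it replaces, yet in this assay the swap gives only (a 1.1-fold higher number from compound 3 to compound 4 (0.03 log units; within the scatter)). The comparisons with the other two aromatic groups are just as small, at (a 1.1-fold lower number from compound 2 to compound 4 (0.03 log units; within the scatter)) and (a 1.1-fold lower number from compound 1 to compound 4 (0.03 log units; within the scatter)), so all four compounds now sit within the scatter of one another and this position shows no measurable preference among the groups tested. No measurement shown offers any reason for this flat picture.

Going by these compounds, all four compounds share the same core, including its long carbon chain, so it remains open whether a shorter chain there would shift the number beyond the scatter. On these data alone, it is equally open whether an amine or a carboxylic acid on the aromatic ring would break the pattern, or whether almost any aromatic group at this position gives a similar reading.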